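Pentafluorophenyl in place of methoxyphenyl on a four-ring core

The source may report more compounds than this note shows. Statements on the series, on what has been measured and on what is new or still open speak of the compounds shown alone.

Measured so far:
compound 1, `C[C@H]1CC[C@@H]2[C@@H](OC(=O)[C@]23CC(c2ccc(F)cc2)=NO3)[C@]2(C)C(=O)C=C[C@@]12O`, 1.58
compound 2, `COc1ccc(C2C[C@@]3(ON2c2ccccc2)C(=O)O[C@@H]2[C@H]3CC[C@H](C)[C@]3(O)C=CC(=O)[C@@]23C)cc1`, 3.25

The two measured compounds share a four-ring core and differ in how the small five-membered ring is built. In a physicochemical assay for lipophilicity (a higher number here means a more lipophilic compound, a lower number a more polar compound), compound 2 gives 3.25, the higher of the two numbers; compound 1 gives 1.58 in this assay, a gap beyond the usual scatter. Among the measured compounds shown here, no single-point step between measured compounds is available, so the next change can be judged only from the structures. Compound 3, `C[C@H]1CC[C@@H]2[C@@H](OC(=O)[C@]23CC(c2c(F)c(F)c(F)c(F)c2F)N(c2ccccc2)O3)[C@]2(C)C(=O)C=C[C@@]12O`, is derived from compound 2 by one change: 2,3,4,5,6-pentafluorophenyl in place of 4-methoxyphenyl on a saturated ring carbon. Because compound 2 already gives 3.25, and fluorine-rich aryl groups with no hydrogen-bond acceptor tend to read higher in this assay, an upward step of moderate size is expected for compound 3, as a number 0.65 log units higher from compound 2 to compound 3 (beyond the scatter). Compound 3 is therefore estimated to give 3.9 in this assay, within a range from 3.3 to 4.5.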

Compound 3, partition coefficient: 3.72
Beside the measured number, compound 3's estimate is 0.18 log units above it; measured number inside the range.
By their numbers in this assay, from the lowest: compound 1; then compound 2; then compound 3.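

In this assay, 2,3,4,5,6-pentafluorophenyl in place of 4-methoxyphenyl on a saturated ring carbon gives a number 0.47 log units higher from compound 2 to compound 3 (beyond the scatter). This is the first step shown that comes from a change in one place only, so it shows that the number responds to the aryl group on this carbon while the rest of the molecule stays the same. Nothing measured here accounts for the size or direction of this step.

Since only these two aryl groups are shown at this carbon, it remains open how this assay would read with a 4-chlorophenyl group, an amine or a carboxylic acid there. The step also cannot separate the loss of the methoxy oxygen from the arrival of the five fluorine atoms, as both come with the same change.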